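The compounds below may be only part of what the source reports. "The series", "measured", "known", "first", "only" and "open" are said of these compounds alone.

Measured so far in an in vitro ADME assay on microsomes from liver (Homo sapiens) for pharmacokinetics, read by LC-MS, with a stated time of 10 min, tested at 1 uM (a lower number here means slower removal, a higher number faster removal of the compound), are these compounds:
- Compound 1 (`CN1C[C@H](C(=O)Nc2ccccc2)[C@@H](c2ccc(/C=C/C(=O)Nc3ccccc3N)cc2)C1`): 7 mL/min/kg
- Compound 2 (`CC(C)c1ccc(NC(=O)[C@H]2CN(C)C[C@@H]2c2ccc(/C=C/C(=O)Nc3ccccc3N)cc2)cc1`): 10 mL/min/kg

For the measured compounds named here, compound 2 stands within the scatter of compound 1, the only other measured compound, so the two cannot be ranked. Compound 3 (`CN1C[C@H](C(=O)Nc2ccc(C(F)(F)F)cc2)[C@@H](c2ccc(/C=C/C(=O)Nc3ccccc3N)cc2)C1`) has not yet been measured. It keeps the core of compound 2 and differs by trifluoromethyl in place of isopropyl on an aromatic carbon (trifluoromethyl in place of isopropyl on an aromatic carbon, para to a large group). Going by the values given here, one measured step touches this place: isopropyl in place of hydrogen gave a 1.4-fold higher number from compound 1 to compound 2 (0.15 log units; within the scatter) and stayed within the scatter. Among the compounds with values here, no measured compound carries trifluoromethyl, so this guide is only indirect. With that one step as the guide, no change beyond the scatter is expected in this assay in either direction. The expected step is a 1.3-fold lower number from compound 2 to compound 3 (0.10 log units; within the scatter) as an estimate. For compound 3 the estimated clearance is 8 mL/min/kg with a likely range of 4 mL/min/kg to 16 mL/min/kg around it.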

Compound 3, clearance: 6 mL/min/kg
Compound 3: middle estimate off by 1.3-fold (0.12 log units), on the high side; the range from low to high includes it.
By their numbers in this assay, from the lowest: compounds 3, 1 and 2 (each within the scatter of the next).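

In this assay, trifluoromethyl in place of isopropyl on the aromatic carbon para to a large group gives a 1.7-fold lower number from compound 2 to compound 3 (0.22 log units; within the scatter), and trifluoromethyl in place of hydrogen gives a 1.2-fold lower number from compound 1 to compound 3 (0.07 log units; within the scatter). Hydrogen, isopropyl and trifluoromethyl at this position therefore cannot be told apart in this assay, whereas the earlier compounds compared only hydrogen with isopropyl. No available evidence bears on why these groups read alike.

On these data alone, it remains open whether a group of another kind at this carbon, such as an amine, a carboxylic acid or a longer chain, would give a step beyond the scatter. The compounds shown also leave open whether trifluoromethyl on another carbon of the same ring would read the same way.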